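The compounds below may be only part of what the source reports. "The series", "measured", "known", "first", "only" and "open" are said of these compounds alone.

Compound 1 `CC(=O)N1c2ccccc2CCC1C(=O)Nc1cc(C(F)(F)F)cc(C(F)(F)F)c1` — > 70000 nM
Compound 2 `CCCC(=O)N1c2ccccc2CCC1C(=O)Nc1ccccc1C(F)(F)F` — > 70000 nM

In a functional assay on NUGC-3 cells (Homo sapiens) for cytotoxicity, read by sulforhodamine B assay, with a stated time of 72 h (on this read-out lower numbers stand for stronger inhibition of growth and higher numbers for weaker inhibition of growth), compound 1 gives > 70000 nM, which is a limit of the assay and not a number. Compound 2 likewise reaches only a limit, > 70000 nM. Both values sit at the limit of > 70000 nM in this assay, at which 2 of the 2 values shown sit, so compound 1 stands on no measured number at all, only at the edge of what this assay can report. Compound 3 `O=C(Nc1cc(C(F)(F)F)cc(C(F)(F)F)c1)C1CCc2ccccc2N1C(=O)c1ccccc1` differs from compound 1 by phenyl in place of methyl on a carbonyl carbon, in words phenyl in place of methyl on a carbonyl carbon, or acetyl to benzoyl. For the measured compounds named here, with no step between measured compounds, the size of this change in this assay cannot be read from the data; the expectation is for no step beyond the scatter, though a larger move in either direction cannot be excluded. Compound 3 is therefore expected at 60000 nM, with a range from 10000 nM to 200000 nM, most likely again reported only as a limit. This estimate implies an at least 1.1-fold lower number from compound 1 to compound 3 (0.06 log units; that floor lies within the scatter), expected to be none beyond the scatter.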

Compound 3, concentration for 50% growth inhibition: 1680 nM
Compound 3: the middle estimate sits 36-fold (1.55 log units) above what was measured, and the stated range ends above it.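

In this assay, replacing methyl with phenyl on a carbonyl carbon, acetyl to benzoyl, gives an at least 41-fold lower number from compound 1 to compound 3 (1.61 log units; beyond the scatter), and this brings the first measured number among the compounds shown. It shows that the group on this carbonyl carbon, whose other neighbour is the amide-type nitrogen in a ring, can decide whether growth inhibition is seen at all on the core of compound 1. Compound 1 has only a limit, so the step gives a floor and not a size: the limit of > 70000 nM in this assay, at which 2 of the 3 values shown sit.

This single pair cannot say whether the aromatic ring or simply the larger group carries the change, and a cyclohexyl or a benzyl group on the same carbonyl carbon would separate the two. Also open, from the compounds shown here alone, is whether a benzoyl group carrying a methoxy group or a chlorine would move the number further.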